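This account rests on a few compounds, and the source may have more. Where it says the series, first, only, none or still open, it means among the compounds named here.

Measured compounds:
- Compound 1, `C=C1C(=O)O[C@@H]2[C@@H]1[C@H](OC(=O)C(C)C)C(=O)[C@@H](C)C[C@H](O)C[C@](C)(O)[C@H]2OC(=O)/C(C)=C\C`, in a functional assay on SK-MEL-2 cells (Homo sapiens) for cytotoxicity, read by sulforhodamine B assay (a lower number here means that less compound is needed, a higher number that more compound is needed for the effect), gives 1.08 ug/mL.
- Compound 2, `C=C1C(=O)O[C@@H]2[C@@H]1[C@H](OC(=O)C(C)C)C(=O)[C@@H](C)C[C@H](O)C[C@](C)(O)[C@H]2OC(=O)C(C)C`, in this assay gives 1.88 ug/mL.

Only these two numbers exist so far. Going by the values given here, compound 2 stands at one end of the pair, yet the single step of a 1.7-fold higher number from compound 1 to compound 2 (0.24 log units; within the scatter) is within the scatter, so compound 1 and compound 2 cannot be told apart on these data.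

Compound 3, `C=C1C(=O)O[C@@H]2[C@@H]1[C@H](OC(=O)C(C)CC)C(=O)[C@@H](C)C[C@H](O)C[C@](C)(O)[C@H]2OC(=O)C(C)C`, has not yet been measured. It differs from compound 2 by methyl in place of hydrogen on a saturated chain carbon, two bonds along the chain from a carbonyl carbon. Among the compounds with values here, no measured step touches this place on the chain: the only step known, a 1.7-fold higher number from compound 1 to compound 2 (0.24 log units; within the scatter), concerns the ester on the other side of the shared core, and even that change stayed within the scatter. There is therefore no measured basis for expecting a movement in either direction, and the small size of the change gives no reason of its own.

For compound 3 the expectation in this assay is 2 ug/mL, with a range from 0.9 ug/mL to 4.5 ug/mL. The step this implies, a 1.1-fold higher number from compound 2 to compound 3 (0.03 log units; within the scatter), is expected to remain within the scatter.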

Compound 3, concentration for half-maximal effect: 1.45 ug/mL
Beside the measured number, compound 3's estimate is 1.4-fold (0.14 log units) above it, within the range that was stated.
By their numbers in this assay, from the lowest: compounds 1, 3 and 2 (each within the scatter of the next).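

In this assay, methyl in place of hydrogen, which turns isopropyl into sec-butyl, gives a 1.3-fold lower number from compound 2 to compound 3 (0.11 log units; within the scatter), so compound 2 and compound 3 cannot be told apart on these data. Going by these compounds alone, this is the first measurement at this place, on a saturated chain carbon, two bonds along the chain from a carbonyl carbon, and it shows that this ester can carry sec-butyl instead of isopropyl with no readable difference in this assay. Nothing measured here offers an explanation for this result.

On these data alone, it remains open whether a longer chain, a phenyl ring, an amine or a carboxylic acid at this place would move the number beyond the scatter, since a single added methyl tests only a very small change. As far as these compounds go, it is also open whether sec-butyl would give a similar result when the ester on the other side of the shared core carries the 1-methylprop-1-en-1-yl group of compound 1 rather than the isopropyl group of compound 2.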